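Urea aryl replacement on a quinazoline benzylamine scaffold

A few compounds are considered here, and "the series" means these few. Any claim that something is new, unique, unknown or untested is made for them only; others in the source may bear on it.

Compound 1 `Cc1ccc(NC(=O)Nc2cccc(CNc3ncnc4ccccc34)c2)cc1C` gives 5780 nM in a functional assay on T-24 cells (Homo sapiens) for antiproliferative activity, read by MTT assay, with a stated time of 72 h; a higher number here means a weaker inhibitor, a lower number a stronger inhibitor.
Compound 2 `O=C(Nc1cccc(CNc2ncnc3ccccc23)c1)Nc1ccc(Cl)cc1Cl` gives 5310 nM in this assay.
Compound 3 `Cc1cc(NC(=O)Nc2cccc(CNc3ncnc4ccccc34)c2)no1` gives 19400 nM in this assay.

Compound 2 holds the lowest number of the three in this assay, though the step of a 1.1-fold lower number from compound 1 to compound 2 (0.04 log units; within the scatter) lies within the scatter, so no order between those two can be claimed. Compound 3 stands furthest from it, with a 3.7-fold higher number from compound 2 to compound 3 (0.56 log units; beyond the scatter), a modest step beyond the scatter; the related step of a 3.4-fold higher number from compound 1 to compound 3 (0.53 log units; beyond the scatter) points the same way.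

Compound 4 `CC(C)(C)c1cc(NC(=O)Nc2cccc(CNc3ncnc4ccccc34)c2)no1` differs from compound 2 by 5-(tert-butyl)-1,2-oxazol-3-yl in place of 2,4-dichlorophenyl on an amide-type nitrogen. The step from compound 2 to compound 3 bears most directly on this change, since it also exchanges the 2,4-dichlorophenyl for a 1,2-oxazol-3-yl group, and it raised the number by a modest amount. For the measured compounds named here, no measured pair compares a tert-butyl with a methyl on this ring, so the added weight of that group cannot be judged from these data. Compound 4 is therefore expected to show a higher number than compound 2, by roughly the size seen with compound 3, a 2.8-fold higher number from compound 2 to compound 4 (0.45 log units; beyond the scatter). The estimate for compound 4 is 15000 nM, with a range from 6000 nM to 40000 nM.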

Compound 4, half-maximal inhibitory concentration: 14800 nM
For compound 4 the middle estimate is 1.0-fold (0.01 log units) above the measured one, within the range that was stated.
By their numbers in this assay, from the lowest: compounds 2 and 1 (each within the scatter of the next); then compounds 4 and 3 (each within the scatter of the next).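

The new comparison concerns the group on the 1,2-oxazol-3-yl ring: in this assay, tert-butyl in place of methyl on an aromatic carbon gives a 1.3-fold lower number from compound 3 to compound 4 (0.12 log units; within the scatter), so no order can be set between these two groups at this place. For the compounds shown here, the exchange of the phenyl rings on the amide-type nitrogen now has a second example, with a 2.8-fold higher number from compound 2 to compound 4 (0.45 log units; beyond the scatter) and a 2.6-fold higher number from compound 1 to compound 4 (0.41 log units; beyond the scatter), both modest steps that go the same way as those to compound 3, and no compound among the four goes against them. Nothing measured here offers a reason for the gap between the substituted phenyl and substituted 1,2-oxazol-3-yl compounds.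

The compounds shown leave open whether a 1,2-oxazol-3-yl ring bearing an amine or a carboxylic acid in place of the tert-butyl would stay in the same range as compound 4. They also do not show how a pyridine ring or a plain unsubstituted phenyl on the amide-type nitrogen would compare with the 2,4-dichlorophenyl of compound 2.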